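Swapping a hydroxypropyl chain for a trifluoromethylphenyl ring

The source may hold more compounds than are shown below. What is called first, only, known or untested is meant among the compounds shown, and "the series" means these compounds.

Of the compounds shown here, three on a shared core have been tested in an ADME assay on HeLa cells (Homo sapiens) for cytotoxicity, read by sulforhodamine B assay, with a stated time of 48 h, tested at 10 uM; on this read-out higher numbers stand for more inhibition at the one concentration tested (going by the name of the read-out) and lower numbers for less inhibition. Compound 1 `COc1nc2ccc(Br)cc2cc1C(c1ccccc1)n1cc(-c2ccccc2F)nn1` gives 14.1%. Compound 2 `CCCCCCCCc1cn(C(c2ccccc2)c2cc3cc(Br)ccc3nc2OC)nn1` gives 0.1%. Compound 3 `COc1nc2ccc(Br)cc2cc1C(c1ccccc1)n1cc(CCCO)nn1` gives 11.3%. On these numbers compound 3 cannot be told apart from compound 1, but it sits clearly above compound 2, since a number 11.2 percentage points higher from compound 2 to compound 3 (beyond the scatter). The widest gap among the three is a number 14 percentage points lower from compound 1 to compound 2 (beyond the scatter).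

Compound 4 `COc1nc2ccc(Br)cc2cc1C(c1ccccc1)n1cc(-c2ccccc2C(F)(F)F)nn1` has not been measured yet. It differs from compound 3 in one place: 2-(trifluoromethyl)phenyl in place of 3-hydroxypropyl on an aromatic carbon. The measured step that bears most directly on this change runs the other way, from 2-fluorophenyl to 3-hydroxypropyl, and was small: a number 2.8 percentage points lower from compound 1 to compound 3 (within the scatter). Putting an aromatic ring back in that place is therefore expected to move the number little, if at all, beyond the scatter. Among the measured compounds shown here, no measured pair compares a 2-(trifluoromethyl)phenyl with a 2-fluorophenyl, so the range around the estimate has to stay wide. Compound 4 is expected to give 14% in this assay, between 3% and 27%, which means an expected step of a number 2.7 percentage points higher from compound 3 to compound 4 (within the scatter).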

Compound 4, a percentage reported as inhibition, at one concentration (the size of the read-out at that concentration, not a potency): -1.3%
Compound 4: middle estimate off by 15.3 percentage points, on the high side; measured number below the stated range.
By their numbers in this assay, from the lowest: compounds 4 and 2 (each within the scatter of the next); then compounds 3 and 1 (each within the scatter of the next).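

Both compound 1 and compound 4 carry a substituted phenyl ring at this position on the shared core, yet in this assay, trifluoromethyl in place of fluoro gives a number 15.4 percentage points lower from compound 1 to compound 4 (beyond the scatter), so an aromatic ring here does not by itself hold the number up, and the group on that ring matters. Replacing 3-hydroxypropyl with 2-(trifluoromethyl)phenyl is likewise not a neutral swap, giving a number 12.6 percentage points lower from compound 3 to compound 4 (beyond the scatter), even though the earlier exchange of 2-fluorophenyl for 3-hydroxypropyl stayed within the scatter; the new ring also lands level with the octyl chain, with a number 1.4 percentage points lower from compound 2 to compound 4 (within the scatter), so two very different groups cannot be told apart here. Nothing measured on these compounds explains why trifluoromethyl and fluoro on the ring differ in this way.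

On these data alone, it remains open whether a plain phenyl ring or a 2-chlorophenyl group would read like compound 1 or like compound 4. As far as these compounds go, it is also open whether a chain ending in an amine or a carboxylic acid would behave like the 3-hydroxypropyl chain of compound 3.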